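Compound 3 to compound 4: changing the ester-bearing group

The source may hold more compounds than are shown below. What is called first, only, known or untested is meant among the compounds shown, and "the series" means these compounds.

Values in a functional assay on HL-60 cells (Homo sapiens), with a stated time of 2 days; a higher number here means a weaker inhibitor, a lower number a stronger inhibitor:
- compound 1 `O=C(Nc1ccc(Cl)c(Cl)c1)c1nc[nH]c1C(=O)NCc1ccc(Cl)cc1`: 16200 nM
- compound 2 `C[C@H](NC(=O)c1[nH]cnc1C(=O)Nc1ccc(Cl)c(Cl)c1)c1ccccc1`: 9200 nM
- compound 3 `C[C@@H](NC(=O)c1[nH]cnc1C(=O)Nc1ccc(Cl)c(Cl)c1)C(=O)OC(C)(C)C`: 4600 nM

Compound 3 stands at the low end of these numbers, with a 2.0-fold lower number from compound 2 to compound 3 (0.30 log units; within the scatter) and a 3.5-fold lower number from compound 1 to compound 3 (0.55 log units; beyond the scatter).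

Compound 4 `COC(=O)[C@@H](NC(=O)c1[nH]cnc1C(=O)Nc1ccc(Cl)c(Cl)c1)C(C)C` carries 1-(methoxycarbonyl)-2-methylpropyl in place of 1-(tert-butoxycarbonyl)ethyl on an amide-type nitrogen.

The same nitrogen also varies in a 1.8-fold lower number from compound 1 to compound 2 (0.25 log units; within the scatter), and in the two steps above. These steps are small to modest, and none compares two esters. No step beyond the scatter is therefore expected in this assay. The expected change is a 1.1-fold higher number from compound 3 to compound 4 (0.04 log units; within the scatter). The estimate for compound 4 is 5000 nM, with an expected range of 1800 nM to 14000 nM.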

Compound 4, half-maximal inhibitory concentration: > 62500 nM
Compound 4: a limit, no number; the forecaster's own chance of this, stated with the estimate: 5%; middle value at least 12-fold (1.09 log units) away from the limit.
By their numbers in this assay, from the lowest: compounds 3, 2 and 1 (each within the scatter of the next, the first and the last beyond it). At a limit, above all of these: compound 4.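

In this assay compound 4 gives > 62500 nM, which is a limit and not a number. Earlier changes on this amide-type nitrogen moved the number little, whereas all three new steps lie beyond the scatter: an at least 13-fold higher number from compound 3 to compound 4 (1.13 log units; beyond the scatter), an at least 6.7-fold higher number from compound 2 to compound 4 (0.83 log units; beyond the scatter) and an at least 3.8-fold higher number from compound 1 to compound 4 (0.58 log units; beyond the scatter). Carrying an ester on this nitrogen therefore does not by itself keep the level of compound 3.

The step alters the ester alkyl group and the carbon chain bearing it together, and the compounds shown do not separate the two. As far as these compounds go, how a free carboxylic acid or a primary amide in place of the ester would read also remains open.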